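Swapping the Ether Aryl Group: Expectation for Compound 4

The source may hold more compounds than are shown below. What is called first, only, known or untested is meant among the compounds shown, and "the series" means these compounds.

Measured compounds:
Compound 1 `Cc1nn(Cc2ccc(C(N)=O)cc2)c(C)c1NC(=O)c1ccc(COc2ccccc2)cc1`: in a functional assay on MIA PaCa-2 cells (Homo sapiens) for antiproliferative activity, read by MTT assay, with a stated time of 72 h (on this read-out higher numbers stand for an effect only at larger amounts of compound and lower numbers for an effect already at smaller amounts), compound 1 gives > 100000 nM, which is the limit of > 100000 nM in this assay, at which 1 of the 3 values shown sits, and not a number.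
Compound 2 `CNC(=O)c1cccc(Cn2nc(C)c(NC(=O)c3ccc(COc4cccc(C)c4)cc3)c2C)c1`: in this assay compound 2 gives 6200 nM.
Compound 3 `CNC(=O)c1cccc(Cn2nc(C)c(NC(=O)c3ccc(COc4ccc(OC)cc4)cc3)c2C)c1`: in this assay compound 3 gives 8000 nM.

Compound 3 holds the higher of the two numbers, its nearest neighbour being compound 2, and the step of a 1.3-fold higher number from compound 2 to compound 3 (0.11 log units; within the scatter) lies within the scatter. The unmeasured compound 4 `CNC(=O)c1cccc(Cn2nc(C)c(NC(=O)c3ccc(COc4cccc(C(F)(F)F)c4)cc3)c2C)c1` differs from compound 3 by 3-(trifluoromethyl)phenyl in place of 4-methoxyphenyl on an oxygen on a saturated carbon. Among the compounds with values here, the only measured step that bears on exchanging the aryl group on this oxygen is a 1.3-fold higher number from compound 2 to compound 3 (0.11 log units; within the scatter), which stayed within the scatter. Since compound 4 exchanges one aryl for another at the same place, no step beyond the scatter is expected in this assay. Compound 4 is therefore expected to give 6500 nM, within 2000 nM to 25000 nM, an expected step of a 1.2-fold lower number from compound 3 to compound 4 (0.09 log units; within the scatter).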

Compound 4, half-maximal effective concentration: 2300 nM
Compound 4: the middle estimate sits 2.8-fold (0.45 log units) above what was measured; the range from low to high includes it.
By their numbers in this assay, from the lowest: compound 4; then compounds 2 and 3 (each within the scatter of the next). At a limit, above all of these: compound 1.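

The aryl group on this oxygen is less freely exchangeable than the earlier pair suggested: replacing 4-methoxyphenyl with 3-(trifluoromethyl)phenyl produces a 3.5-fold lower number from compound 3 to compound 4 (0.54 log units; beyond the scatter) in this series. Trifluoromethyl in place of methyl on an aromatic carbon, a change in one group only, produces a 2.7-fold lower number from compound 2 to compound 4 (0.43 log units; beyond the scatter) and also moves beyond the scatter. Nothing measured here explains either step.

The compounds shown leave open how an aryl group carrying an amine or a carboxylic acid would read at this place.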